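A few compounds are considered here, and "the series" means these few. Any claim that something is new, unique, unknown or untested is made for them only; others in the source may bear on it.

Measured compounds:

Compound 1, `Nc1nn2c(O)cc(-c3ccccc3F)nc2c1[N+](=O)[O-]`. In a functional assay on K562 cells (Homo sapiens) for inhibition (a higher number here means a weaker inhibitor of growth, a lower number a stronger inhibitor of growth), compound 1 gives only a limit, > 50 ug/mL.

Compound 2, `NNCc1cc(O)n2nc(N)c([N+](=O)[O-])c2n1`. In this assay compound 2 gives 26.5 ug/mL.

Compound 2 holds the only number shown in this assay; the other value is a limit. Among the measured compounds shown here, the single measured step is an at least 1.8-fold lower number from compound 1 to compound 2 (0.27 log units; that floor lies within the scatter), and because one of the two values sits at the limit of > 50 ug/mL in this assay, at which 1 of the 2 values shown sits, the comparison yields no more than that floor, which lies within the scatter. Compound 3, `Nc1nn2c(O)cc(CNNc3ccc(F)cc3)nc2c1[N+](=O)[O-]`, is not yet measured; it differs from compound 2 by 4-fluorophenyl in place of hydrogen on an amine nitrogen. For the measured compounds named here, no measured step touches this amine nitrogen, and the one step that exists, at another place, was small. No change beyond the scatter is therefore expected in this assay. Compound 3 is expected to give about 20 ug/mL, between 6 ug/mL and 60 ug/mL, meaning an expected step of a 1.3-fold lower number from compound 2 to compound 3 (0.12 log units; within the scatter).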

Compound 3, concentration for 50% growth inhibition: 19.7 ug/mL
Compound 3: middle estimate off by 1.0-fold (0.01 log units), on the high side, within the range that was stated.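

In this assay, this amine nitrogen now has a measured change, which the earlier step at another place could not supply, and the result is a 1.3-fold lower number from compound 2 to compound 3 (0.13 log units; within the scatter). Hydrogen on this amine nitrogen can therefore be exchanged for 4-fluorophenyl, with its six-membered aromatic ring of carbon, without a step beyond the scatter. This holds for this single pair only, and the two compounds cannot be told apart in this assay.

From the compounds shown here alone, whether an unsubstituted phenyl, a carboxylic acid or a longer chain on the same amine nitrogen would leave the read-out in this assay equally unmoved stays open, since this position rests on one step. Compound 1 still stands only as a limit: the limit of > 50 ug/mL in this assay, at which 1 of the 3 values shown sits.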